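This account rests on a few compounds, and the source may have more. Where it says the series, first, only, none or still open, it means among the compounds named here.

Four compounds built on one shared core are compared here for their effect on a breast-tumour cell line. Compound 1 is `O=C(O[C@H]1C[C@H](n2cc(F)c(=O)[nH]c2=O)O[C@@H]1COP(=O)(O)Oc1cccnc1)c1ccccc1`, and in a functional assay on T47D cells (Homo sapiens) for cytotoxicity, read by MTT assay, with a stated time of 48 h (on this read-out lower numbers stand for stronger inhibition and higher numbers for weaker inhibition), compound 1 gives 14400 nM. Compound 2 is `O=C(O[C@H]1C[C@H](n2cc(F)c(=O)[nH]c2=O)O[C@@H]1COP(=O)(O)Oc1ccc2ncccc2c1)c1ccccc1`; it differs from compound 1 by quinolin-6-yl in place of pyridin-3-yl on an oxygen, and in this assay compound 2 gives 7140 nM. That change made a step of a 2.0-fold lower number from compound 1 to compound 2 (0.30 log units; within the scatter), a step that stays inside the range in which repeated measurements of this kind normally wander.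

Compound 3 is `O=c1[nH]c(=O)n([C@H]2C[C@H](O)[C@@H](COP(=O)(O)Oc3cccnc3)O2)cc1F`. Its core differs from that of compound 1 by hydrogen in place of benzoyl on an oxygen on a saturated carbon, and in this assay compound 3 gives 9350 nM, a step of a 1.5-fold lower number from compound 1 to compound 3 (0.19 log units; within the scatter). The values of compound 2 and compound 3 lie close to each other, and neither of them can be told apart from the other with confidence.

Compound 4 is `O=c1[nH]c(=O)n([C@H]2C[C@H](O)[C@@H](COP(=O)(O)Oc3ccc4ncccc4c3)O2)cc1F`, not yet measured in this assay. It differs from compound 3 by quinolin-6-yl in place of pyridin-3-yl on an oxygen, on a place described in the same words as for the pair of compound 1 and compound 2, so the change is the same one seen once already. Among the compounds with values here, the expectation for compound 4 is a step of a 1.7-fold lower number from compound 3 to compound 4 (0.23 log units; within the scatter), resting on the single earlier instance of this change, which moved compound 1 to compound 2 by a 2.0-fold lower number from compound 1 to compound 2 (0.30 log units; within the scatter). Compound 4 is therefore estimated at 5500 nM in this assay, with a likely range from 2500 nM to 12000 nM, and the measured value will show how far one observation of a change carries over to a different core.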

Compound 4, half-maximal inhibitory concentration: 8110 nM
Estimate against measurement, compound 4: 1.5-fold (0.17 log units) below; the measured number falls inside the stated range.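

In this assay, quinolin-6-yl in place of pyridin-3-yl on the core without the benzoyl group makes a step of a 1.2-fold lower number from compound 3 to compound 4 (0.06 log units; within the scatter), and hydrogen in place of benzoyl with quinolin-6-yl present makes a step of a 1.1-fold higher number from compound 2 to compound 4 (0.06 log units; within the scatter), so the first change looks no different on the two cores: the same change on two cores in this assay, a 2.0-fold lower number (0.30 log units; within the scatter) from compound 1 to compound 2 and a 1.2-fold lower number (0.06 log units; within the scatter) from compound 3 to compound 4, 1.7-fold (0.24 log units) apart, within the scatter of two such steps

The second change also looks no different on its two cores, and this agreement is the limit of what can be said, since each single step is small enough to be ordinary repeat-to-repeat wandering: the same change on two cores in this assay, a 1.5-fold lower number (0.19 log units; within the scatter) from compound 1 to compound 3 and a 1.1-fold higher number (0.06 log units; within the scatter) from compound 2 to compound 4, 1.7-fold (0.24 log units) apart, within the scatter of two such steps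

The four compounds therefore show that neither change gives a measurable difference on either core, but they do not show that either change has a real effect of a given size that carries from one core to the other.

From the compounds shown here alone, it remains open whether an acetyl group or a longer acyl chain such as palmitoyl in place of benzoyl, or a plain phenyl in place of pyridin-3-yl on the oxygen bound to phosphorus, would move the number beyond the scatter. Only a step of that size could give a real test of whether a change carries over between these cores.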